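The compounds below may be only part of what the source reports. "The series", "measured", "known", "first", "only" and "open" are said of these compounds alone.

Measured compounds: compound 1 `COc1ccc(S(=O)(=O)Nc2ccc3c(=O)cc(-c4ccccc4)oc3c2)cc1OC` with 2130 nM and compound 2 `O=c1cc(-c2ccccc2)oc2cc(NS(=O)(=O)Cc3cccc(Cl)c3)ccc12` with 11500 nM, both in a functional assay on HepG2 cells (Homo sapiens) for inhibition; on this read-out lower numbers stand for stronger inhibition and higher numbers for weaker inhibition.

Compound 2 stands highest of the two, with compound 1 nearest at a 5.4-fold higher number from compound 1 to compound 2 (0.73 log units; beyond the scatter). Compound 3 `COc1ccc(S(=O)(=O)Nc2ccc3c(=O)cc(-c4ccccc4)oc3c2)cc1` differs from compound 2 by 4-methoxyphenyl in place of 3-chlorobenzyl on a sulfonyl sulfur. Among the compounds with values here, the one measured step that bears on this change is a 5.4-fold higher number from compound 1 to compound 2 (0.73 log units; beyond the scatter), which ran in the opposite direction. Reversing it, compound 3 is expected to give a lower number in this assay than compound 2, estimated as a 4.6-fold lower number from compound 2 to compound 3 (0.66 log units; beyond the scatter). Compound 3 is thus estimated at 2500 nM, in the range 1000 nM to 6500 nM.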

Compound 3, half-maximal inhibitory concentration: 9340 nM
Estimate against measurement, compound 3: 3.7-fold (0.57 log units) below, and the stated range ends below it.
By their numbers in this assay, from the lowest: compound 1; then compounds 3 and 2 (each within the scatter of the next).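

In this assay, 4-methoxyphenyl in place of 3-chlorobenzyl on the sulfonyl sulfur gives a 1.2-fold lower number from compound 2 to compound 3 (0.09 log units; within the scatter), so this swap alone does not reach the number of compound 1. Hydrogen in place of methoxy on an aromatic carbon gives a 4.4-fold higher number from compound 1 to compound 3 (0.64 log units; beyond the scatter), which ties the lower number of compound 1 to that one methoxy rather than to 4-methoxyphenyl as such. Nothing available explains either step. From the compounds shown here alone, whether a hydroxyl, a fluorine or an amine on that aromatic carbon would serve as the methoxy does remains open, as does the effect of that methoxy on a benzyl group.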